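Working notes: the step from compound 3 to compound 4

A few compounds are considered here, and "the series" means these few. Any claim that something is new, unique, unknown or untested is made for them only; others in the source may bear on it.

compound 1 `OC[C@H]1O[C@@H](n2cnc3c(NCc4cccc(F)c4)ncnc32)[C@H](O)[C@@H]1O` gives 4000 nM
compound 2 `OC[C@H]1O[C@@H](n2cnc3c(NCc4ccc(Cl)cc4)ncnc32)[C@H](O)[C@@H]1O` gives 10200 nM
compound 3 `OC[C@H]1O[C@@H](n2cnc3c(NCc4c(F)ccc(F)c4F)ncnc32)[C@H](O)[C@@H]1O` gives 90300 nM

All three values come from a functional assay on CCRF-CEM cells (Homo sapiens) for antiproliferative activity, with a stated time of 72 h (on this read-out higher numbers stand for weaker inhibition and lower numbers for stronger inhibition), and compound 3 carries the highest number of the set. It is the weakest of the three, with both steps towards it beyond the scatter (a 23-fold higher number from compound 1 to compound 3 (1.35 log units; beyond the scatter)) and (an 8.9-fold higher number from compound 2 to compound 3 (0.95 log units; beyond the scatter)).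

Compound 4 `OC[C@H]1O[C@@H](n2cnc3c(NCc4ccc(F)cc4Cl)ncnc32)[C@H](O)[C@@H]1O` is still unmeasured. The change is 2-chloro-4-fluorophenyl in place of 2,3,6-trifluorophenyl on a saturated chain carbon bound to a nitrogen on an aromatic ring with 2-chloro-4-fluorophenyl in place of 2,3,6-trifluorophenyl on a saturated chain carbon bound to a nitrogen on an aromatic ring.

Among the measured compounds shown here, no measured compound carries the entering group, so the evidence is indirect. The two steps above bear on the change, one large and one modest, and the step between the two lower compounds is smaller (a 2.6-fold higher number from compound 1 to compound 2 (0.41 log units; beyond the scatter)). Both compounds without the 2,3,6-trifluorophenyl group sit lower than compound 3, though three compounds establish no rule. A modest move to a lower number is therefore expected in this assay and the closest guide is compound 2 (10200 nM). The estimated step is a decrease (a 6.0-fold lower number from compound 3 to compound 4 (0.78 log units; beyond the scatter)). Compound 4 is expected at 15000 nM (estimated range 4000 nM to 50000 nM).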

Compound 4, half-maximal inhibitory concentration: 20900 nM
Beside the measured number, compound 4's estimate is 1.4-fold (0.14 log units) below it; low and high end bracket the measured number.
By their numbers in this assay, from the lowest: compound 1; then compound 2; then compound 4; then compound 3.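

In this assay, 2-chloro-4-fluorophenyl on a saturated chain carbon bound to a nitrogen on an aromatic ring is better tolerated than 2,3,6-trifluorophenyl, with a 4.3-fold lower number from compound 3 to compound 4 (0.64 log units; beyond the scatter), so the high number of compound 3 does not extend to every phenyl group carrying more than one halogen. The new group still does not match either group carrying a single halogen, with a 2.0-fold higher number from compound 2 to compound 4 (0.31 log units; beyond the scatter) and a 5.2-fold higher number from compound 1 to compound 4 (0.72 log units; beyond the scatter), which places compound 4 in an intermediate position in the series. Across these four compounds the number rises with the count of halogen atoms on the phenyl group, and none goes against that order, but the halogen count changes together with the identity and placement of the halogens, so these compounds do not separate the three.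

Open questions are whether the order extends to unsubstituted phenyl, to a phenyl group bearing an amine or a methoxy group, or to a longer chain in place of the saturated chain carbon. No measurement here accounts for the differences among these halogenated groups.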